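A few compounds are considered here, and "the series" means these few. Any claim that something is new, unique, unknown or untested is made for them only; others in the source may bear on it.

Compound 1 `Cc1cnc(Nc2ccc(F)cc2)nc1Nc1nc2ccccc2s1` in a functional assay on PC-3 cells (Homo sapiens) for antiproliferative activity, read by MTT assay, with a stated time of 48 h (on this read-out lower numbers stand for stronger inhibition and higher numbers for weaker inhibition), gives > 50000 nM, a limit of the assay. Compound 2 `COc1ccc(Nc2ncc(C)c(Nc3nc4ccccc4s3)n2)cc1` gives > 50000 nM, also a limit.

Compound 2 therefore stands only at the limit, as does the other measured compound, which is what the limit of > 50000 nM in this assay, at which 2 of the 2 values shown sit, records. The step that the two limits leave unreadable from compound 1 to compound 2 cannot be read between two limits. Compound 3 `Cc1cnc(Nc2ccc(N3CCCCC3)cc2)nc1Nc1nc2ccccc2s1` carries piperidin-1-yl in place of methoxy on an aromatic carbon. No readable measured step bears on this change, so no size or direction can be drawn from the data. Compound 3 is expected to give about 40000 nM in this assay, between 5000 nM and 100000 nM. The expected step is an at least 1.2-fold lower number from compound 2 to compound 3 (0.09 log units; that floor lies within the scatter), an estimate rather than an inference.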

Compound 3, half-maximal inhibitory concentration: > 50000 nM
Compound 3 ended at the assay's limit (the forecaster's own chance of this, stated with the estimate: 60%); at least 1.2-fold (0.09 log units) between middle value and limit.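

Compound 3 stands at the limit of the assay, as do compound 1 and compound 2, so no step among the three can be read: the limit of > 50000 nM in this assay, at which 3 of the 3 values shown sit.

The compounds shown leave open whether fluoro, methoxy or piperidin-1-yl differ at all in their effect on these cells.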